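Hydrazone aryl swap on the pyrazole carbohydrazide series

The source may report more compounds than this note shows. Statements on the series, on what has been measured and on what is new or still open speak of the compounds shown alone.

Measured so far:
- compound 1 `O=C(N/N=C/c1ccccc1O)c1cc(-c2ccc(Cl)cc2)nn1Cc1ccc(Cl)nc1`: 270 nM
- compound 2 `CC(C)(C)c1ccc(Cn2nc(-c3ccc(Cl)cc3)cc2C(=O)N/N=C/c2ccc(F)cc2F)cc1`: 21900 nM

In a functional assay on NCI-H23 cells (Homo sapiens) for antiproliferative activity, read by BrdU incorporation, with a stated time of 48 h (on this read-out lower numbers stand for stronger inhibition and higher numbers for weaker inhibition), compound 1 gives 270 nM, the lower of the two numbers. Compound 2 gives 21900 nM, a number far higher and beyond the scatter; the two compounds differ in more than one place, so the two values alone are all that can be said of that pair.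

Compound 3 `N#Cc1ccc(/C=N/NC(=O)c2cc(-c3ccc(Cl)cc3)nn2Cc2ccc(Cl)nc2)cc1` is not yet measured. It differs from compound 1 by 4-cyanophenyl in place of 2-hydroxyphenyl on a carbon with a double bond to nitrogen. For the measured compounds named here, no single-change step exists to calibrate this swap. The group entering brings no hydrogen-bond donor where one leaves, and the step of a 5.6-fold higher number from compound 1 to compound 3 (0.74 log units; beyond the scatter) from compound 1 to compound 3 is expected to run toward weaker inhibition, most likely beyond the scatter. Compound 3 is estimated at 1500 nM, within 300 nM to 8000 nM.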

Compound 3, half-maximal inhibitory concentration: > 100000 nM
Compound 3: a limit, no number; the forecaster's own chance of this, stated with the estimate: 10%; middle value at least 66-fold (1.82 log units) away from the limit.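

In this assay, the group on the carbon with a double bond to nitrogen can decide activity on the core of compound 1: 4-cyanophenyl in place of 2-hydroxyphenyl gives an at least 370-fold higher number from compound 1 to compound 3 (2.56 log units; beyond the scatter). For the compounds shown here, compound 1 and compound 2 differ in more than one place, so this is the first reading of this position on its own. The value of compound 3 is a limit of the assay and not a number, so the step has a floor but no fixed size: the limit of > 100000 nM in this assay, at which 1 of the 3 values shown sits.

Going by these compounds alone, still open is whether the loss follows the departure of 2-hydroxyphenyl or the arrival of 4-cyanophenyl, as the one step changes both at once. Unsubstituted phenyl or 4-hydroxyphenyl at the same place would separate the two readings.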